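Chain Lengthening on the Tetrazole Acid of Compound 3

This account rests on a few compounds, and the source may have more. Where it says the series, first, only, none or still open, it means among the compounds named here.

Measured compounds and their values in an in vivo functional assay on the whole organism (Rattus norvegicus) with cysteinyl leukotriene receptor (Homo sapiens) as the target; on this read-out higher numbers stand for an effect only at larger amounts of compound and lower numbers for an effect already at smaller amounts:
compound 1, `CCCc1c(COc2ccc(C(=O)C(C)Cc3nnn[nH]3)cc2)ccc(C(C)=O)c1O`, 9.2 mg/kg;
compound 2, `CCCc1c(COc2ccc(C(=O)CCCCCCc3nnn[nH]3)cc2)ccc(C(C)=O)c1O`, 8.5 mg/kg;
compound 3, `CCCc1c(COc2ccc(Cc3nnn(CCCC(=O)O)n3)cc2)ccc(C(C)=O)c1O`, 19.6 mg/kg.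

Compound 3 gives the highest number of the three in this assay: its nearest neighbour is compound 1 and its furthest is compound 2, both gaps beyond the scatter. Compound 4, `CCCc1c(COc2ccc(Cc3nnn(CCCCC(=O)O)n3)cc2)ccc(C(C)=O)c1O`, differs from compound 3 by carboxymethyl in place of carboxy on a saturated chain carbon, three bonds along the chain from an aromatic nitrogen. Going by the values given here, the only measured step that also lengthens a saturated chain, a 1.1-fold lower number from compound 1 to compound 2 (0.03 log units; within the scatter), stayed within the scatter, though it sits on a different part of the shared core. From that single step an effect beyond the scatter is not expected for compound 4, and compound 4 is therefore estimated at 20 mg/kg, with a range from 9 mg/kg to 45 mg/kg, meaning an expected step of a 1.0-fold higher number from compound 3 to compound 4 (0.01 log units; within the scatter).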

Compound 4, dose for half-maximal effect: 7 mg/kg
Estimate against measurement, compound 4: 2.9-fold (0.46 log units) above; the measured number lies below the stated range.
By their numbers in this assay, from the lowest: compounds 4, 2 and 1 (each within the scatter of the next); then compound 3.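

The 4-carboxybutyl chain of compound 4 in place of the 3-carboxypropyl chain gives a 2.8-fold lower number from compound 3 to compound 4 (0.45 log units; beyond the scatter) in this assay, so lengthening at this position does change the read-out. The only earlier chain-lengthening step, a 1.1-fold lower number from compound 1 to compound 2 (0.03 log units; within the scatter) on a different part of the shared core, had not shown this. No measurement at hand accounts for the change.

Whether a longer chain would lower the number further remains open, since only this single lengthening is shown here. Also open, on these data alone, is how an amide or a tetrazole in place of the carboxylic acid would read at this position.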